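This account rests on a few compounds, and the source may have more. Where it says the series, first, only, none or still open, it means among the compounds named here.

Compound 3 `Cn1cc(-c2cc(C(O)(C(F)(F)F)C(F)(F)F)cnc2N2CCN(S(=O)(=O)c3ccc(N)nc3)CC2)cn1` is examined in an ADME assay (liver) for metabolic stability, with Liver microsome (Homo sapiens) as the target, using microsomes and NADPH, with a stated time of 30 min, tested at 1 uM (on this read-out higher numbers stand for fast clearance and lower numbers for slow clearance), where compound 3 gives 19 mL.min-1.g-1. Compound 1 `COCC#Cc1cc(C(O)(C(F)(F)F)C(F)(F)F)cnc1N1CCN(S(=O)(=O)c2ccc(N)nc2)CC1` gives 15 mL.min-1.g-1 in this assay, and the step of a 1.3-fold higher number from compound 1 to compound 3 (0.10 log units; within the scatter) lies within the scatter. Compound 2 `Nc1ccc(S(=O)(=O)N2CCN(c3ncc(C(O)(C(F)(F)F)C(F)(F)F)cc3C#CCCO)CC2)cn1` gives only a limit, < 14 mL.min-1.g-1, in this assay. The step of an at least 1.3-fold higher number from compound 2 to compound 3 (0.13 log units; that floor lies within the scatter) and the step of an at least 1.0-fold lower number from compound 1 to compound 2 (0.02 log units; that floor lies within the scatter) both rest on that limit. Compound 2 thus sits at the limit of < 14 mL.min-1.g-1 in this assay, at which 1 of the 3 values shown sits. On the numbers shown, compound 3 stands close to compound 1, separated from it by nothing beyond the scatter, and only a floor is known for the gap to compound 2.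

Compound 4 `Nc1ccc(S(=O)(=O)N2CCN(c3ncc(C(O)(C(F)(F)F)C(F)(F)F)cc3-c3ccc4scnc4c3)CC2)cn1` has not yet been measured in this assay. It differs from compound 3 by 1,3-benzothiazol-5-yl in place of 1-methyl-1H-pyrazol-4-yl on an aromatic carbon. Among the measured compounds shown here, the two measured steps that alter the group on this aromatic carbon, the one from compound 1 and the one from compound 2, both stay within the scatter, so exchanging a small group at that position has so far left this assay unmoved. For the measured compounds named here, the group entering here is larger than any tried so far, and no measured step covers a change of this size. Compound 4 is therefore expected to show a step of a 1.8-fold higher number from compound 3 to compound 4 (0.27 log units; within the scatter), a moderate rise, and its value in this assay is estimated at 35 mL.min-1.g-1, between 15 mL.min-1.g-1 and 80 mL.min-1.g-1.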

Compound 4, intrinsic clearance in microsomes: 39 mL.min-1.g-1
For compound 4 the middle estimate is 1.1-fold (0.05 log units) below the measured one; low and high end bracket the measured number.
By their numbers in this assay, from the lowest: compounds 1 and 3 (each within the scatter of the next); then compound 4. At a limit, below all of these: compound 2.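

In this assay, the aromatic carbon ortho to a large group and two atoms from the ring nitrogen proves able to move the read-out beyond the scatter: exchanging 1-methyl-1H-pyrazol-4-yl for 1,3-benzothiazol-5-yl gives a 2.1-fold higher number from compound 3 to compound 4 (0.31 log units; beyond the scatter), whereas the steps from compound 1 and compound 2 to compound 3 showed nothing beyond it. The same entering group, set against 3-methoxyprop-1-yn-1-yl, gives a 2.6-fold higher number from compound 1 to compound 4 (0.41 log units; beyond the scatter), so the rise does not depend on the pyrazole as the point of comparison. Against 4-hydroxybut-1-yn-1-yl the change gives an at least 2.7-fold higher number from compound 2 to compound 4 (0.44 log units; beyond the scatter), and that figure is only a floor set by the limit of compound 2: the limit of < 14 mL.min-1.g-1 in this assay, at which 1 of the 4 values shown sits.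

The entering group brings more heavy atoms, a sulfur and a six-membered aromatic ring of carbon only all at once, so the compounds shown cannot say which of these goes with the rise. As far as these compounds go, whether a phenyl group or a 1,3-benzoxazol-5-yl group, with oxygen where the sulfur stands, on this carbon would stay within the scatter of compound 3 remains open.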